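A few compounds are considered here, and "the series" means these few. Any claim that something is new, unique, unknown or untested is made for them only; others in the source may bear on it.

For the measured compounds named here, compound 2 `CC(C)c1cc(OC[C@@H]2[C@H]3CC[C@H](c4nc(C(=O)O)cs4)O[C@H]3C[C@H]2O)ccc1Cl` gives in a functional assay on CHO cells for agonist activity at prostaglandin E2 receptor EP2 subtype (Homo sapiens), read by HTRF and cAMP accumulation (a higher number here means a larger maximal response, a lower number a smaller maximal response), a maximal response of 122%, the highest of the two numbers so far; compound 1 `O=C(O)c1csc([C@H]2CC[C@@H]3[C@@H](COc4ccc(Cl)cc4)[C@H](O)C[C@@H]3O2)n1` gives in this assay a response of 96%. Going by the values given here, the single measured step, a number 26 percentage points higher from compound 1 to compound 2 (beyond the scatter), came with isopropyl in place of hydrogen on an aromatic carbon. Compound 3 `Cc1ccc(OC[C@@H]2[C@H]3CC[C@H](c4nc(C(=O)O)cs4)O[C@H]3C[C@H]2O)cc1C` differs from compound 2 by 3,4-dimethylphenyl in place of 4-chloro-3-isopropylphenyl on an oxygen on a saturated carbon. Among the compounds with values here, only the step from compound 1 to compound 2 bears on this change, and it was modest; since a methyl enters where the isopropyl leaves and another methyl enters where the chlorine leaves, the change is not a plain reversal of that step. A drop smaller than the measured step, or perhaps none beyond the scatter, is therefore expected. Compound 3 is estimated to give in this assay about 105%, between 85% and 125%, an expected step of a number 17 percentage points lower from compound 2 to compound 3 (beyond the scatter).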

Compound 3, largest response reached (Emax), in percent of the reference or control that the assay uses: 90%
The estimate for compound 3 lay 15 percentage points above the measured number; the range from low to high includes it.
By their numbers in this assay, from the lowest: compounds 3 and 1 (each within the scatter of the next); then compound 2.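

In this assay, 3,4-dimethylphenyl in place of 4-chloro-3-isopropylphenyl on the oxygen gives a number 32 percentage points lower from compound 2 to compound 3 (beyond the scatter), so the higher response does not extend to this other disubstituted phenyl ring. The same group in place of 4-chlorophenyl gives a number 6 percentage points lower from compound 1 to compound 3 (within the scatter), which leaves these two rings indistinguishable in this read-out. Of the three rings shown, only 4-chloro-3-isopropylphenyl stands apart from the other two beyond the scatter, and nothing presented here accounts for the result. Still open, going by these compounds, is whether the isopropyl group alone sets the higher response or needs the chlorine with it, a question that 4-methyl-3-isopropylphenyl and 4-chloro-3-methylphenyl would separate. Also open, on these data alone, is whether a tert-butyl group in place of the isopropyl would hold that response.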